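Ester in place of the pendant aryl on the anilino series

This account rests on a few compounds, and the source may have more. Where it says the series, first, only, none or still open, it means among the compounds named here.

Measured so far:
compound 1 `COc1ccc(NC2=CC(=O)c3ncncc3C2=O)cc1` — 1900 nM
compound 2 `CCc1ccc(-c2ccc(NC3=CC(=O)c4ncncc4C3=O)cc2)cc1` — 2000 nM

In a functional assay on MIA PaCa-2 cells (Homo sapiens) for cytotoxicity, read by MTT assay, with a stated time of 72 h (on this read-out lower numbers stand for stronger inhibition and higher numbers for weaker inhibition), compound 1 gives 1900 nM. In this assay compound 2 gives 2000 nM. For the measured compounds named here, the one measured step, a 1.1-fold higher number from compound 1 to compound 2 (0.02 log units; within the scatter), is within the scatter, so compound 2 and compound 1 cannot be told apart on these numbers; compound 2 simply sits beside the only other measured compound.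

Compound 3 `CCOC(=O)c1ccc(NC2=CC(=O)c3ncncc3C2=O)cc1` is the next candidate. Relative to compound 2 the change is ethoxycarbonyl in place of 4-ethylphenyl on an aromatic carbon. Going by the values given here, the only step that bears on this position is the one from compound 1 to compound 2, which swapped the group at the same aromatic carbon and left the number within the scatter. With nothing else to draw on, the working expectation for this assay is no step beyond the scatter, though an ester is a different kind of group from either of the two measured ones, so the range is kept wide. Compound 3 is therefore expected at 2000 nM, between 700 nM and 6000 nM. The expected step is no change at the digits printed from compound 2 to compound 3 (within the scatter).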

Compound 3, half-maximal inhibitory concentration: 5500 nM
Compound 3: the middle estimate sits 2.8-fold (0.44 log units) below what was measured; measured number inside the range.
By their numbers in this assay, from the lowest: compounds 1 and 2 (each within the scatter of the next); then compound 3.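

Notes on the aromatic carbon para to a large group: in this assay this place is not indifferent to what it carries, as the step between methoxy and 4-ethylphenyl alone had suggested. Ethoxycarbonyl gives a 2.8-fold higher number from compound 2 to compound 3 (0.44 log units; beyond the scatter) and a 2.9-fold higher number from compound 1 to compound 3 (0.46 log units; beyond the scatter) as its two steps, so it is the first group in the series to move the number beyond the scatter, and it moves it towards weaker inhibition, though only modestly. No measurement on hand accounts for this change and the steps stand as observations only.

Open, from the compounds shown here alone, is whether the shift belongs to the ester as a whole or to its ethyl part, which a carboxylic acid or a primary amide on the same carbon would help to separate. Also open, going by these compounds, is whether an amine there would move the number the other way.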